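The compounds below may be only part of what the source reports. "The series", "measured", "known", "first", "only" and "open" are said of these compounds alone.

Compound 1 `CN(Cc1ccc2nccn2c1)c1nnc(-c2ccc(-c3ccccc3F)cc2)o1` – 15.9 nM in an assay on isolated protein for inhibition of tyrosine-protein kinase Mer (Homo sapiens), read by LC-MS; on this read-out lower numbers stand for stronger inhibition and higher numbers for weaker inhibition
Compound 2 `Cc1ccccc1-c1ccc(-c2nnc(N(C)Cc3ccc4nccn4c3)o2)cc1` – 12.6 nM in this assay

Compound 2 has the lowest of the two numbers, but its gap to compound 1 is within the scatter: a 1.3-fold lower number from compound 1 to compound 2 (0.10 log units; within the scatter). So the two compounds cannot be told apart on these data. Compound 3 `Cc1ncccc1-c1ccc(-c2nnc(N(C)Cc3ccc4nccn4c3)o2)cc1` is not yet measured. The change from compound 2 to compound 3 is 2-methylpyridin-3-yl in place of 2-methylphenyl on an aromatic carbon. No measured step is of this kind; the only step shown, methyl in place of fluoro, swaps a small group and was within the scatter. Nothing here tells how a ring nitrogen at this place affects the number in this assay. The expected step is therefore a 1.3-fold higher number from compound 2 to compound 3 (0.10 log units; within the scatter), with a wide range to allow for an unknown effect. For compound 3 the estimate in this assay is 16 nM, between 6 nM and 45 nM.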

Compound 3, half-maximal inhibitory concentration: 50.1 nM
Beside the measured number, compound 3's estimate is 3.1-fold (0.50 log units) below it, and the stated range ends below it.
By their numbers in this assay, from the lowest: compounds 2 and 1 (each within the scatter of the next); then compound 3.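

This place on the core is not indifferent in this assay. Exchanging fluoro for methyl on the ring here left the number within the scatter, but 2-methylpyridin-3-yl in place of 2-methylphenyl gives a 4.0-fold higher number from compound 2 to compound 3 (0.60 log units; beyond the scatter), although both groups have the same count of heavy atoms and the entering ring differs by one nitrogen, counted as one hydrogen-bond acceptor. Measured against the fluorinated ring, 2-methylpyridin-3-yl in place of 2-fluorophenyl gives a similar result, a 3.2-fold higher number from compound 1 to compound 3 (0.50 log units; beyond the scatter), so the higher number holds against both carbon-only rings shown.

Going by these compounds, it remains open whether a pyridine with its nitrogen elsewhere in the ring would read the same, and how a ring carrying an amine or a carboxylic acid would fare. Nothing available gives a reason for the rise.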